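The source may report more compounds than this note shows. Statements on the series, on what has been measured and on what is new or still open speak of the compounds shown alone.

Measured in an assay on tissue (PBMC cells) for antagonist activity at Toll-like receptor 9 (Homo sapiens); a higher number here means a weaker inhibitor, a lower number a stronger inhibitor:
compound 1, `Cc1cc(-c2nn(C)c3nc(N)ncc23)cnc1OCC12CCC(N)(CC1)CC2`, gives 3300 nM
compound 2, `Cn1nc(-c2ccc(OC[C@H]3CC[C@@H](N)CC3)c(F)c2)c2cnc(N)nc21`, gives 2200 nM
compound 3, `Cc1cc(-c2ccnc3[nH]ncc23)cnc1OCC12CCC(N)(CC1)CC2`, gives 1000 nM

Compound 2 holds the second highest of the three numbers. Its gap to compound 1 lies within the scatter, so no order between those two is claimed; its gap to compound 3 lies beyond the scatter, compound 3 giving the lower number.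

The next compound is compound 4, `Cn1nc(-c2ccc(OCCCC3CCNCC3)c(F)c2)c2cnc(N)nc21`. Relative to compound 2 the change is 2-(piperidin-4-yl)ethyl in place of 4-aminocyclohexyl on a saturated chain carbon bound to an oxygen on an aromatic ring. The count of donors and acceptors is unchanged and the ring size is kept, while the chain grows and the ring gains its nitrogen. Among the compounds with values here, no measured pair in this set mirrors this change, so the expectation rests on compound 2 alone. A step of modest size, in either direction, is expected, most likely not beyond the scatter; the step of a 1.4-fold higher number from compound 2 to compound 4 (0.13 log units; within the scatter) is the estimate. Compound 4 is expected to give about 3000 nM, within 1000 nM to 9000 nM.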

Compound 4, half-maximal inhibitory concentration: 2300 nM
Compound 4: middle estimate off by 1.3-fold (0.12 log units), on the high side; the measured number falls inside the stated range.
By their numbers in this assay, from the lowest: compound 3; then compounds 2, 4 and 1 (each within the scatter of the next).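

At the saturated chain carbon bound to an oxygen on an aromatic ring, 2-(piperidin-4-yl)ethyl in place of 4-aminocyclohexyl gives, in this assay, a 1.0-fold higher number from compound 2 to compound 4 (0.02 log units; within the scatter). This position therefore accepts a longer chain, a nitrogen within the ring and the loss of both defined stereocentres with no readable shift in the number. Nothing available explains this flat result.

The ring nitrogen and the longer chain enter together, so their separate contributions remain unresolved. On these data alone, whether a plain cyclohexyl, carrying no amine, would hold the number also stays open.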